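This account rests on a few compounds, and the source may have more. Where it says the series, first, only, none or still open, it means among the compounds named here.

Measured so far in a functional assay on CHO-K1 cells for antagonist activity at adenosine receptor A1 (Homo sapiens), read by a beta-galactosidase reporter and cAMP accumulation, with stated times of 15 min and 6 h; a lower number here means a stronger inhibitor, a higher number a weaker inhibitor:

Compound 1, `Nc1nc(-c2ccc(C3CC3)o2)nc2sc(Cc3ccccc3)cc12`, gives 861 nM.
Compound 2, `N#Cc1ccc(-c2nc(N)c3cc(Cc4ccccc4)sc3n2)o1`, gives 3160 nM.
Compound 3, `N#Cc1cccc(-c2nc(N)c3cc(Cc4ccccc4)sc3n2)c1`, gives 222 nM.

Compound 3 stands lowest of the three in this assay, that is, it is the strongest inhibitor shown: there is a 3.9-fold lower number from compound 1 to compound 3 (0.59 log units; beyond the scatter), and there is a 14-fold lower number from compound 2 to compound 3 (1.15 log units; beyond the scatter). Both steps swap the whole ring hanging off the shared core.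

Compound 4, `Nc1nc(-c2cccc(F)c2)nc2sc(Cc3ccccc3)cc12`, keeps the ring of compound 3 and changes only the group on it: fluoro in place of cyano on an aromatic carbon. The change sits on an aromatic carbon of a six-membered aromatic ring of carbon only, meta to a large group.

Among the compounds with values here, only one measured step changes a group at that place rather than the ring itself: a 3.7-fold higher number from compound 1 to compound 2 (0.56 log units; beyond the scatter), where cyano entered in place of cyclopropyl on the furan ring and the number rose modestly. Within the data shown here, no measured compound carries fluoro, so nothing shows how a fluorine atom compares with a nitrile here. Going from cyano to fluoro reverses the kind of change seen from compound 1 to compound 2, but on a different ring, so the expected step is small and uncertain, most likely a modest rise in the number.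

Compound 4 is therefore estimated at 500 nM in this assay, with a plausible range from 150 nM to 1800 nM. The step this estimate implies is a 2.3-fold higher number from compound 3 to compound 4 (0.35 log units; beyond the scatter).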

Compound 4, inhibition constant: 123 nM
Beside the measured number, compound 4's estimate is 4.1-fold (0.61 log units) above it; measured number below the stated range.
By their numbers in this assay, from the lowest: compounds 4 and 3 (each within the scatter of the next); then compound 1; then compound 2.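

In this assay, replacing the nitrile with fluoro on this phenyl ring gives a step within the usual scatter (a 1.8-fold lower number from compound 3 to compound 4 (0.26 log units; within the scatter)), so the two groups cannot be told apart at this place, even though they differ in size and only the nitrile counts as a hydrogen-bond acceptor. The phenyl ring keeps its lead over the furan compounds when it carries fluoro, as the two ring swaps show (a 26-fold lower number from compound 2 to compound 4 (1.41 log units; beyond the scatter); a 7.0-fold lower number from compound 1 to compound 4 (0.85 log units; beyond the scatter)), so the earlier result with 3-cyanophenyl is not specific to the nitrile. Nothing measured here explains why the two groups read alike or why the phenyl compounds differ from the furan compounds.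

From the compounds shown here alone, whether this place would accept very different groups, such as an amine, a carboxylic acid or a methoxy group, equally well remains open. It is also open how a plain phenyl ring with neither fluoro nor nitrile would compare, so the compounds shown cannot say whether either group adds anything to the ring itself.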